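Benzylamide series: M5 modulation, halogen shift on the benzyl ring

The compounds below may be only part of what the source reports. "The series", "measured", "known", "first", "only" and "open" are said of these compounds alone.

Measured compounds and their largest response:
- compound 1 `CCN(Cc1ccccc1)C(=O)C1CCN(S(=O)(=O)c2ccc3cn[nH]c3c2)CC1`: 86%
- compound 2 `CCN(Cc1ccc(F)cc1)C(=O)C1CCN(S(=O)(=O)c2ccc3cn[nH]c3c2)CC1`: 55%
- compound 3 `CCN(Cc1ccccc1F)C(=O)C1CCN(S(=O)(=O)c2ccc3cn[nH]c3c2)CC1`: 84%

All three share one core and differ only in the ring attached to the saturated chain carbon bound to the amide-type nitrogen. In a functional assay on CHO cells for positive allosteric modulation of muscarinic acetylcholine receptor M5 (Homo sapiens), read by calcium flux (a higher number here means a larger maximal response, a lower number a smaller maximal response), compound 3 stands second highest of the three numbers; its nearest neighbour is compound 1, which lies within the scatter of it, and its furthest is compound 2, which lies beyond the scatter below it. The steps measured so far: a number 31 percentage points lower from compound 1 to compound 2 (beyond the scatter); a number 2 percentage points lower from compound 1 to compound 3 (within the scatter); a number 29 percentage points higher from compound 2 to compound 3 (beyond the scatter).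

Compound 4 `CCN(Cc1cccc(Cl)c1)C(=O)C1CCN(S(=O)(=O)c2ccc3cn[nH]c3c2)CC1` is not yet measured. Its difference from compound 3: 3-chlorophenyl in place of 2-fluorophenyl on a saturated chain carbon bound to an amide-type nitrogen. Within the data shown here, no measured step covers a 3-chlorophenyl, and none covers chlorine at all. What the series shows is that one substituent on this ring left the response unchanged while another cut it sharply, so the direction of this step is open. Because of a number 31 percentage points lower from compound 1 to compound 2 (beyond the scatter) a large drop is possible; because of a number 2 percentage points lower from compound 1 to compound 3 (within the scatter) no change is equally possible. The expected step for compound 4 is therefore a number 14 percentage points lower from compound 3 to compound 4 (beyond the scatter), a modest lowering at the middle of a wide range. For compound 4 the estimated value is 70%, expected between 45% and 92%.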

Compound 4, largest response reached (reported as percent of maximum), in percent of the reference or control that the assay uses: 77%
For compound 4 the middle estimate is 7 percentage points below the measured one, and the stated range covers the measured number.
By their numbers in this assay, from the lowest: compound 2; then compounds 4, 3 and 1 (each within the scatter of the next).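

Chlorine now has a measured case on the ring at this place, on a saturated chain carbon bound to an amide-type nitrogen. In this assay, chloro in place of hydrogen gives no step beyond the scatter (a number 9 percentage points lower from compound 1 to compound 4 (within the scatter)), and 3-chlorophenyl in place of 2-fluorophenyl gives none either (a number 7 percentage points lower from compound 3 to compound 4 (within the scatter)), so a halogen on this ring does not by itself bring a large loss. The 4-fluorophenyl goes against that level response and remains the only ring shown that stands apart, with 3-chlorophenyl in its place giving a clear rise (a number 22 percentage points higher from compound 2 to compound 4 (beyond the scatter)), and nothing available here accounts for that difference.

Going by these compounds, whether the loss seen with the 4-fluorophenyl goes with fluorine or with where the halogen sits stays open, and a 4-chlorophenyl and a 3-fluorophenyl would separate the two. Also open, on these data alone, is whether the maximal response holds with a substituent other than a halogen on this ring, such as a methoxy group or a carboxylic acid.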